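The source may report more compounds than this note shows. Statements on the series, on what has been measured and on what is new or still open speak of the compounds shown alone.

In a functional assay on MIA PaCa-2 cells (Homo sapiens) for cytotoxicity, read by fluorescence, with a stated time of 48 h (a lower number here means that less compound is needed, a higher number that more compound is needed for the effect), compound 1 (`CC(C)=CCC/C(C)=C/CC/C(C)=C/CSC[C@H](NC(=O)CCCCCN1CCN(C)CC1)C(=O)NC1CC1`) gives 10400 nM. Two related compounds offer a comparison: compound 2 (`CC(C)=CCC/C(C)=C/CC/C(C)=C/CSC[C@H](NC(=O)CCCCCN1CCCC1)C(=O)N1CCCCC1`) gives 12400 nM, and compound 3 (`CC(C)=CCC/C(C)=C/CC/C(C)=C/CSC[C@H](NC(=O)CCCCCN1CCCC1)C(=O)NC1CCCCCC1`) gives 6800 nM. Compound 1 lies within the scatter of both, so these numbers set no firm order among the three.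

Compound 4 (`CC(C)=CCC/C(C)=C/CC/C(C)=C/CSC[C@H](NC(=O)CCCCCN1CCN(C)CC1)C(=O)NC1CCCC1`) differs from compound 1 in one place: cyclopentyl in place of cyclopropyl on an amide-type nitrogen. In words, this is cyclopentyl in place of cyclopropyl on an amide-type nitrogen, or cyclopropylcarbamoyl to cyclopentylcarbamoyl when cut one bond further out.

Going by the values given here, no measured pair makes this exact exchange. The closest evidence is a 1.8-fold lower number from compound 2 to compound 3 (0.26 log units; within the scatter), where cycloheptylamino takes the place of piperidin-1-yl on a carbonyl carbon. That step also changes the group on the carbonyl, but it is a different exchange and is made on compounds whose other amide chain differs from that of compound 1. It stays within the scatter, so it offers only weak guidance. In this assay, no shift beyond the scatter is expected, with at most a slight lean towards a lower number. The expected change is a 1.3-fold lower number from compound 1 to compound 4 (0.11 log units; within the scatter), which would remain within the scatter. For compound 4 the estimate is 8000 nM, with an expected range of 4500 nM to 14000 nM.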

Compound 4, half-maximal effective concentration: 10900 nM
Beside the measured number, compound 4's estimate is 1.4-fold (0.13 log units) below it; measured number inside the range.
By their numbers in this assay, from the lowest: compounds 3, 1, 4 and 2 (each within the scatter of the next).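

In this assay, the exchange of cyclopropyl for cyclopentyl on an amide-type nitrogen now has a direct reading, free of any other change in the molecule: a 1.0-fold higher number from compound 1 to compound 4 (0.02 log units; within the scatter). The earlier compounds shown here could speak to this position only through a different exchange, made on compounds with a different amide chain, whereas this pair keeps the rest of compound 1 intact. Going from a three-membered to a five-membered carbon ring here therefore leaves the number within the scatter, and nothing available explains why the number stays put.

Going by these compounds alone, the pair covers only two saturated carbon rings, so it remains open whether a phenyl ring, or a chain ending in an amine or a carboxylic acid, on this same nitrogen would move the number beyond the scatter. As far as these compounds go, it is also open whether the same exchange would behave alike on compounds carrying the pyrrolidin-1-yl chain of compound 2 and compound 3 rather than the chain shared by compound 1 and compound 4.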